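Furan in place of difluorophenyl on the fused core

This account rests on a few compounds, and the source may have more. Where it says the series, first, only, none or still open, it means among the compounds named here.

Compound 3 `Cc1cc(NCc2ccccn2)n2ncc(-c3ccc(F)cc3F)c2n1` carries a 2,4-difluorophenyl group on the fused core shared by the series. In a physicochemical assay for solubility, read by HPLC, using the shake flask method, measured as kinetic solubility, with a stated time of 2 h, at pH 7.4 (on this read-out higher numbers stand for higher solubility and lower numbers for lower solubility), compound 3 gives < 5000 nM, which is a limit of the assay and not a number. Compound 1 `Cc1cc(NCc2ccccn2)n2ncc(-c3ccccc3F)c2n1` gives 5000 nM in this assay. Compound 2 `Cc1cc(NCc2ccccn2)n2ncc(-c3ccc(F)c(Cl)c3)c2n1` gives < 5000 nM in this assay, again a limit. The measured steps are therefore weak guides: a number no higher from compound 1 to compound 3 (the limit leaves the size open) and a number no higher from compound 1 to compound 2 (the limit leaves the size open), while a step that the two limits leave unreadable from compound 2 to compound 3. The common feature is the limit of < 5000 nM in this assay, at which 2 of the 3 values shown sit, so none of the three steps has a readable size.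

Compound 4 `Cc1cc(NCc2ccccn2)n2ncc(-c3ccco3)c2n1` differs from compound 3 in one place: furan-2-yl in place of 2,4-difluorophenyl on an aromatic carbon. Going by the values given here, no measured step replaces the phenyl ring itself; the three recorded steps only change halogens within a phenyl ring and leave their sizes open, so no direction can be read from them for this exchange. The expectation is set near the limit where compound 3 sits, with wide uncertainty. Compound 4 is expected to give 8000 nM in this assay, within a range of 3000 nM to 25000 nM. The step that this estimate means is an at least 1.6-fold higher number from compound 3 to compound 4 (0.20 log units; that floor lies within the scatter), which is expected but not readable against a starting value that is itself a limit.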

Compound 4, solubility: 48800 nM
For compound 4 the middle estimate is 6.1-fold (0.79 log units) below the measured one, and the stated range ends below it.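

Going by these compounds alone, replacing the halogenated phenyl ring with furan-2-yl on this aromatic carbon gives the first step of exact size in this assay: the pair with an exact value at both ends shows a 9.8-fold higher number from compound 1 to compound 4 (0.99 log units; beyond the scatter), beyond anything the halogen changes among the phenyl compounds allowed to be read. The other two pairs agree in direction, with an at least 9.7-fold higher number from compound 3 to compound 4 (0.98 log units; beyond the scatter) and an at least 9.7-fold higher number from compound 2 to compound 4 (0.98 log units; beyond the scatter), so all three phenyl compounds shown sit on the lower side of this exchange. Those two steps give only a floor for the size because their starting values are limits: the limit of < 5000 nM in this assay, at which 2 of the 4 values shown sit.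

The exchange changes several things at once, from a six-membered ring of carbon only to a five-membered ring with a ring oxygen, a hydrogen-bond acceptor and fewer heavy atoms, and the compounds shown cannot separate these. As far as these compounds go, whether thiophene, which keeps the five-membered ring without the oxygen, or a phenyl ring carrying an amine would give a step of similar size at this carbon remains open.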